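The source may report more compounds than this note shows. Statements on the series, on what has been measured and on what is new or still open speak of the compounds shown alone.

Measured so far:
- compound 1, `COc1ccc(C2=NN(c3nc(-c4ccc(Br)cc4)cs3)C(c3cccs3)C2)cc1`: 5870 nM
- compound 2, `Fc1ccc(C2=NN(c3nc(-c4ccc(Br)cc4)cs3)C(c3cccs3)C2)cc1`: 220 nM

Both numbers come from a functional assay on WM 266-4 cells (Homo sapiens) for antiproliferative activity, read by MTT assay, with a stated time of 48 h; a lower number here means a stronger inhibitor, a higher number a weaker inhibitor. Among the compounds with values here, of the two, compound 2 stands lowest, and the only measured step, a 27-fold lower number from compound 1 to compound 2 (1.43 log units; beyond the scatter), sets it well apart from compound 1. That step swaps a group on one aromatic ring while everything else stays the same.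

Compound 3, `Fc1ccc(C2=NN(c3nc(-c4ccccc4)cs3)C(c3cccs3)C2)cc1`, has not been measured yet. It differs from compound 2 by hydrogen in place of bromo on an aromatic carbon; cut one bond further out, the change reads 4-bromophenyl to phenyl. Within the data shown here, the single measured step touches a different part of the molecule, not the bromo, so nothing measured here bears directly on this change. With no guide from the measured pair, the expectation is that removing the bromo costs some potency rather than adding any, giving an expected step of a 2.0-fold higher number from compound 2 to compound 3 (0.31 log units; beyond the scatter) in this assay. The estimate for compound 3 is therefore 450 nM, with a likely range from 130 nM to 1600 nM.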

Compound 3, half-maximal inhibitory concentration: 170 nM
Beside the measured number, compound 3's estimate is 2.6-fold (0.42 log units) above it; low and high end bracket the measured number.
By their numbers in this assay, from the lowest: compounds 3 and 2 (each within the scatter of the next); then compound 1.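

Compound 2 and compound 3 cannot be told apart in this assay: the step is a 1.3-fold lower number from compound 2 to compound 3 (0.11 log units; within the scatter), so the bromine atom on this phenyl ring is not needed for the antiproliferative activity of this series, and plain hydrogen serves as well. Within the data shown here, this site therefore behaves quite differently from the one probed earlier, on the other phenyl ring, where fluoro in place of methoxy gave a 27-fold lower number from compound 1 to compound 2 (1.43 log units; beyond the scatter), so in these three compounds only that earlier swap separates the numbers by more than the scatter. No measurement is available to explain why the bromine atom can be removed without a clear loss of activity.

The compounds shown test only bromo and hydrogen at this position, so a single pair cannot show whether the site tolerates anything placed there; a small amine, a carboxylic acid or a longer chain such as butyl might behave quite differently. As far as these compounds go, it also remains open whether the bromo matters when methoxy rather than fluoro sits on the other ring, as one step in a single cell line cannot say whether the two sites act independently.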